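The source may report more compounds than this note shows. Statements on the series, on what has been measured and on what is new or still open speak of the compounds shown alone.

Measured so far:
compound 1 `Cc1ccc(C)c(-c2nc(CN3CCC(C(=O)NCCCN4C[C@H](C)C[C@H](C)C4)CC3)c(C)o2)c1`, 4070 nM
compound 2 `Cc1ccccc1-c1nc(CN2CCC(C(=O)NCCCN3CC4CCCC(C4)C3)CC2)c(C)o1`, 10900 nM

In an ADME assay on Huh7.5.1 cells (Homo sapiens) for cytotoxicity, read by ATP content, with a stated time of 48 h (a lower number here means that less compound is tolerated, a higher number that more compound is tolerated), compound 1 gives 4070 nM, the lowest of the two numbers; compound 2 gives 10900 nM, a higher number that lies beyond the usual scatter. Compound 3 `COc1ccc(-c2nc(CN3CCC(C(=O)NCCCN4C[C@H](C)C[C@H](C)C4)CC3)c(C)o2)cc1OC` has not yet been measured. It differs from compound 1 in one place: 3,4-dimethoxyphenyl in place of 2,5-dimethylphenyl on an aromatic carbon. Within the data shown here, no step between measured compounds touches this change, so the expectation for compound 3 rests on compound 1 alone. For compound 3 a modest rise in the tolerated concentration is expected, a 1.5-fold higher number from compound 1 to compound 3 (0.17 log units; within the scatter). Compound 3 is therefore estimated at 6000 nM, within a range from 2500 nM to 15000 nM.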

Compound 3, half-maximal cytotoxic concentration: 57200 nM
Compound 3: middle estimate off by 9.5-fold (0.98 log units), on the low side; the measured number lies above the stated range.
By their numbers in this assay, from the lowest: compound 1; then compound 2; then compound 3.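

In this assay, 3,4-dimethoxyphenyl in place of 2,5-dimethylphenyl on this aromatic carbon gives a 14-fold higher number from compound 1 to compound 3 (1.15 log units; beyond the scatter), so a change at this position alone can move the tolerated concentration by a large step. The earlier compounds shown here offered no step between measured compounds that showed this. Because the whole aryl group is exchanged, the step cannot be assigned to one part of it, such as the two oxygen atoms or the loss of the methyl groups. On these data alone, whether a single methoxy group on the phenyl ring, or a pyridine in its place, would give a similar step remains open. Nothing measured here gives a reason for the step.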